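Swapping a piperidine for a lactam on the shared core

The source may hold more compounds than are shown below. What is called first, only, known or untested is meant among the compounds shown, and "the series" means these compounds.

Measured so far:
compound 1, `O=C(O)/C=C/c1ccc2noc(-c3ccc(-c4ccccc4)cc3)c2c1`: 74 nM
compound 2, `CNC(=O)c1ccc2noc(-c3ccccc3)c2c1`: 2120 nM
compound 3, `O=C(O)c1ccc2noc(-c3ccc(N4CCCCC4)cc3)c2c1`: 240 nM

Of the compounds shown here, three built on one core have been tested in an assay for inhibition of inositol hexakisphosphate kinase 2 (Homo sapiens), read by colorimetric assay, coupled enzyme assay and malachite green, with a stated time of 120 min, in the presence of a further agent that is not named here; on this read-out lower numbers stand for stronger inhibition and higher numbers for weaker inhibition. Compound 3 gives 240 nM, which is the second highest of the three numbers: compound 1 gives 74 nM, a lower number and a gap beyond the usual scatter, while compound 2 gives 2120 nM, a higher number and also a gap beyond the scatter.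

The next compound, compound 4, `O=C(O)c1ccc2noc(-c3ccc(N4CCCC4=O)cc3)c2c1`, differs from compound 3 in one place: 2-oxopyrrolidin-1-yl in place of piperidin-1-yl on an aromatic carbon. The ring keeps its size in heavy atoms but shrinks by one member and gains a carbonyl.

Among the measured compounds shown here, no measured pair shows this kind of exchange, so the direction is uncertain. A modest step toward a higher number, possibly none beyond the scatter, seems most likely. The expected step from compound 3 to compound 4 is a 1.7-fold higher number from compound 3 to compound 4 (0.22 log units; within the scatter). For compound 4 the estimate in this assay is 400 nM, with a range from 120 nM to 1400 nM.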

Compound 4, half-maximal inhibitory concentration: 480 nM
The estimate for compound 4 lay 1.2-fold (0.08 log units) below the measured number; measured number inside the range.
By their numbers in this assay, from the lowest: compound 1; then compounds 3 and 4 (each within the scatter of the next); then compound 2.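

In this assay, replacing piperidin-1-yl with 2-oxopyrrolidin-1-yl on this aromatic carbon gives a 2.0-fold higher number from compound 3 to compound 4 (0.30 log units; within the scatter), so the two groups cannot be told apart here. Among the compounds shown here, this is the first sign that this place can take a five-membered ring with a carbonyl in place of a six-membered ring without one, with no step beyond the scatter, although ring size and carbonyl change together and neither can be judged alone. Nothing available explains this result.

Going by these compounds, the separate roles of ring size and carbonyl remain open: 2-oxopiperidin-1-yl would keep the six-membered ring with a carbonyl, while pyrrolidin-1-yl would keep the five-membered ring without one. Also open, on these data alone, is how an open-chain group such as dimethylamino would compare with these rings at this place.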